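Trimethoxyphenyl Amide on a Cytotoxic Core

The source may report more compounds than this note shows. Statements on the series, on what has been measured and on what is new or still open speak of the compounds shown alone.

Compound 3 `Cc1ccc(C(=O)NC2=C(C#N)C(c3ccc(Cl)cc3Cl)C3=C(CCCC3=O)N2c2ccc(S(N)(=O)=O)cc2)cc1` carries a 4-methylphenyl on the amide carbonyl of a shared core. In a functional assay on Ehrlich cells (Mus musculus) for cytotoxicity, read by trypan blue exclusion, with a stated time of 2 h (a higher number here means a weaker inhibitor, a lower number a stronger inhibitor), compound 3 reaches only a limit, > 100 ug/mL, so no number is known for it; this is the limit of > 100 ug/mL in this assay, at which 1 of the 3 values shown sits. Two measured companions frame it. Compound 1 `N#CC1=C(NC(=O)C2CC2)N(c2ccc(S(N)(=O)=O)cc2)C2=C(C(=O)CCC2)C1c1ccc(Cl)cc1Cl`, with a cyclopropyl in the same place, gives 75 ug/mL in this assay. Compound 2 `N#CC1=C(NC(=O)c2ccccc2)N(c2ccc(S(N)(=O)=O)cc2)C2=C(C(=O)CCC2)C1c1ccc(Cl)cc1Cl`, with a plain phenyl there, gives 10 ug/mL. The step of a 7.5-fold lower number from compound 1 to compound 2 (0.88 log units; beyond the scatter) is the only one beyond the scatter that strengthens inhibition; the step of an at least 10-fold higher number from compound 2 to compound 3 (1.00 log units; beyond the scatter) goes the other way, and an at least 1.3-fold higher number from compound 1 to compound 3 (0.12 log units; that floor lies within the scatter) cannot be separated from the scatter. Compound 4 `COc1cc(C(=O)NC2=C(C#N)C(c3ccc(Cl)cc3Cl)C3=C(CCCC3=O)N2c2ccc(S(N)(=O)=O)cc2)cc(OC)c1OC` differs from compound 3 by 3,4,5-trimethoxyphenyl in place of 4-methylphenyl on a carbonyl carbon. Among the measured compounds shown here, the one measured change on that aromatic ring, the methyl from compound 2 to compound 3, weakened inhibition by at least a modest step; three methoxy groups are a larger change on the same ring, and no measured step points to a gain. The estimate for compound 4 is therefore 150 ug/mL, between 40 ug/mL and 500 ug/mL, most likely again a limit rather than a number. The step that the limit leaves unreadable from compound 3 to compound 4 is thus expected to be none beyond the scatter.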

Compound 4, half-maximal inhibitory concentration: 60 ug/mL
The estimate for compound 4 lay 2.5-fold (0.40 log units) above the measured number; the measured number falls inside the stated range.
By their numbers in this assay, from the lowest: compound 2; then compounds 4 and 1 (each within the scatter of the next). At a limit, above all of these: compound 3.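

In this assay, the 3,4,5-trimethoxyphenyl on the carbonyl carbon gives a readable number, so a substituted ring at this position need not end at a limit, yet it still weakens inhibition relative to the plain phenyl, with a 6.0-fold higher number from compound 2 to compound 4 (0.78 log units; beyond the scatter). The cyclopropyl and the 3,4,5-trimethoxyphenyl cannot be told apart here, with a 1.3-fold lower number from compound 1 to compound 4 (0.10 log units; within the scatter), so two very different groups on this carbonyl carbon give the same result within the scatter. The comparison with the 4-methylphenyl, an at least 1.6-fold lower number from compound 3 to compound 4 (0.22 log units; that floor lies within the scatter), does not separate the two rings, and compound 3 itself is a limit and not a number: the limit of > 100 ug/mL in this assay, at which 1 of the 4 values shown sits.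

The compounds shown leave open whether a single methoxy group, or an amine or a hydroxyl on the same ring, would keep the number of compound 2 or lose it as compounds 3 and 4 do. Also open, going by these compounds, is how a longer carbon chain on the carbonyl carbon would compare with the cyclopropyl of compound 1.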